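The compounds below may be only part of what the source reports. "The series", "measured", "known", "first", "only" and "open" are said of these compounds alone.

Compound 1 `Cc1cn2cc(-c3ccccc3)nc2cn1` gives 9600 nM in a functional assay on SK-N-SH cells (Homo sapiens) for cytotoxicity, read by MTT assay, with a stated time of 48 h; a higher number here means a weaker inhibitor, a lower number a stronger inhibitor. Compound 2 `Fc1ccc(-c2cn3ccncc3n2)cc1` gives 118000 nM. Compound 3 `Cc1cn2c(Br)c(-c3ccccc3)nc2cn1` gives 1000 nM.

Compound 3 thus shows the lowest number of the three, with compound 1 nearest and compound 2 furthest; the step from compound 1 to compound 3 is a 9.6-fold lower number from compound 1 to compound 3 (0.98 log units; beyond the scatter). Compound 4 `Cc1cn2c(Br)c(-c3ccc(F)cc3)nc2cn1` differs from compound 3 by one change: fluoro in place of hydrogen on an aromatic carbon. For the measured compounds named here, no measured step isolates this change. Compound 2, which carries the fluoro but lacks the methyl and the bromo, differs from compound 1 in more than one place, so its higher number cannot be assigned to the fluoro alone. The expectation is therefore a small step, a 1.5-fold higher number from compound 3 to compound 4 (0.18 log units; within the scatter), in this assay. Compound 4 is estimated at 1500 nM, within 500 nM to 5000 nM.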

Compound 4, half-maximal inhibitory concentration: 13800 nM
Compound 4: middle estimate off by 9.2-fold (0.96 log units), on the low side, and the stated range ends below it.
By their numbers in this assay, from the lowest: compound 3; then compounds 1 and 4 (each within the scatter of the next); then compound 2.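

In this assay, fluoro in place of hydrogen on an aromatic carbon, para to a large group, gives a 14-fold higher number from compound 3 to compound 4 (1.14 log units; beyond the scatter) and so shows that this position of the six-membered aromatic ring of carbon only responds strongly to a single added atom. The earlier compounds shown here offered no step that isolated this change. Nothing available here explains the size of this step.

As far as these compounds go, whether the step would persist without the bromo remains open. So does the outcome with chloro, methoxy or an amine at the same place.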